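A few compounds are considered here, and "the series" means these few. Any claim that something is new, unique, unknown or untested is made for them only; others in the source may bear on it.

Measured so far:
compound 1, `N=C(N)NCCC[C@H](NC(=O)CN(c1ncnc2c1ncn2C1CCCCO1)C1CC1)C(=O)OCc1ccccc1`, 52.4%
compound 2, `CC(C)[C@H](NC(=O)CN(c1ncnc2c1ncn2C1CCCCO1)C1CC1)C(=O)OCc1ccccc1`, 34.9%
compound 3, `O=C(CN(c1ncnc2c1ncn2C1CCCCO1)C1CC1)N[C@@H](CCC(=O)OCc1ccccc1)C(=O)OCc1ccccc1`, 34.7%

All three were tested in a functional assay on the whole organism (Tail, strain ICR) with Mus musculus as the target, in the tail flick test, with a stated time of 60 min, at a dose of 25 umol/kg by the oral route; on this read-out lower numbers stand for a weaker effect and higher numbers for a stronger effect at the one dose given. Compound 3 gives the lowest of the three numbers, yet its nearest neighbour is compound 2, which gives 34.9%, a gap within the scatter; the only clear separation is from compound 1, since the step of a number 17.7 percentage points lower from compound 1 to compound 3 (beyond the scatter) lies beyond the scatter.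

Compound 4 is `CC(C)(C)OC(=O)NCCCC[C@H](NC(=O)CN(c1ncnc2c1ncn2C1CCCCO1)C1CC1)C(=O)OCc1ccccc1`. It differs from compound 3 in one place: 2-((tert-butoxycarbonyl)amino)ethyl in place of benzyloxycarbonyl on a saturated chain carbon, three bonds along the chain from an amide-type nitrogen and a carbonyl carbon.

Among the measured compounds shown here, two measured steps bear on this. The step of a number 17.7 percentage points lower from compound 1 to compound 3 (beyond the scatter) removed a nitrogen-containing group at this same place and brought in the benzyloxycarbonyl group, a modest loss. The step of a number 0.2 percentage points lower from compound 2 to compound 3 (within the scatter) exchanged groups on the chain carbon bound to the amide-type nitrogen and the carbonyl carbon with no change beyond the scatter. Compound 4 brings one nitrogen back at the same place, but inside a quite different group, so only a small rise is expected, a number 6.3 percentage points higher from compound 3 to compound 4 (within the scatter), within the scatter. The estimate for compound 4 is 41%, with a range from 26% to 58%.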

Compound 4, a percentage reported as activity, at one dose (the size of the read-out at that dose, not a potency): 32.7%
Compound 4: the middle estimate sits 8.3 percentage points above what was measured; measured number inside the range.
By their numbers in this assay, from the lowest: compounds 4, 3 and 2 (each within the scatter of the next); then compound 1.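

In this assay, the aromatic ring of the benzyloxycarbonyl group proves dispensable at this position: the ring-free 2-((tert-butoxycarbonyl)amino)ethyl group, with its one hydrogen-bond donor, gives a number 2 percentage points lower from compound 3 to compound 4 (within the scatter). The long 4-((tert-butoxycarbonyl)amino)butyl chain also stands level with the small isopropyl group, at a number 2.2 percentage points lower from compound 2 to compound 4 (within the scatter), while a nitrogen capped in this way does not restore the level of compound 1, as a number 19.7 percentage points lower from compound 1 to compound 4 (beyond the scatter) shows. No measurement given here explains these steps.

As far as these compounds go, compound 1 alone stands clear of the other compounds, so it remains open what a free amine at the end of the same chain, as in 4-aminobutyl, would give. From the compounds shown here alone, a carboxylic acid in place of the benzyl ester on the side chain of compound 3 is equally open.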